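Aryl swap at the ring amide-type nitrogen: compound 3

The source may report more compounds than this note shows. Statements on the series, on what has been measured and on what is new or still open speak of the compounds shown alone.

Going by the values given here, compound 2 `Cc1ccc(S(=O)(=O)Nc2ccc3c(c2)C(=O)N(Cc2ccccc2F)C3=O)cc1` in an assay on isolated protein for inhibition of lysosomal alpha-glucosidase (Rattus norvegicus), read by colorimetric assay (a higher number here means a weaker inhibitor, a lower number a stronger inhibitor), gives 195000 nM, the highest of the two numbers so far; compound 1 `Cc1ccc(S(=O)(=O)Nc2ccc3c(c2)C(=O)N(Cc2ccc(Cl)cc2)C3=O)cc1` gives 188000 nM, and the step of a 1.0-fold higher number from compound 1 to compound 2 (0.02 log units; within the scatter) stays within the scatter. Compound 3 `Cc1ccc(S(=O)(=O)Nc2ccc3c(c2)C(=O)N(Cc2ccc(Cl)c(Cl)c2)C3=O)cc1` differs from compound 2 by 3,4-dichlorophenyl in place of 2-fluorophenyl on a saturated chain carbon bound to an amide-type nitrogen in a ring. Among the compounds with values here, the only measured step at this position, a 1.0-fold higher number from compound 1 to compound 2 (0.02 log units; within the scatter), exchanged one halogenated phenyl for another and moved nothing beyond the scatter, so an aryl exchange on this carbon has so far left this assay unchanged. Within the data shown here, no measured step adds a second chlorine, so the direction of any shift is open. Compound 3 is therefore expected to change little, the estimated step being a 1.1-fold lower number from compound 2 to compound 3 (0.03 log units; within the scatter). The estimate for compound 3 in this assay is 180000 nM, with a range from 90000 nM to 380000 nM.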

Compound 3, half-maximal inhibitory concentration: 122000 nM
Compound 3: the middle estimate sits 1.5-fold (0.17 log units) above what was measured; the range from low to high includes it.
By their numbers in this assay, from the lowest: compounds 3, 1 and 2 (each within the scatter of the next).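

In this assay, adding a chlorine to the aryl ring gives a 1.5-fold lower number from compound 1 to compound 3 (0.19 log units; within the scatter) for chloro in place of hydrogen on an aromatic carbon, and the full aryl exchange gives a 1.6-fold lower number from compound 2 to compound 3 (0.20 log units; within the scatter) for 3,4-dichlorophenyl in place of 2-fluorophenyl. Neither step leaves the scatter, so the result extends the earlier finding from a one-for-one halogenated phenyl exchange to a phenyl carrying an extra chlorine, and the three halogenated phenyl groups on this saturated chain carbon cannot be told apart. No supporting data bear on this result.

As far as these compounds go, all three compounds carry a halogenated phenyl at this position, so it stays open whether a phenyl carrying a carboxylic acid or an amine would give a step beyond the scatter. From the compounds shown here alone, whether a longer chain between the ring amide-type nitrogen and the aryl group would do so is equally open.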